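Swapping the Amide Aryl Group: From Compound 3 to Compound 4

The compounds below may be only part of what the source reports. "The series", "measured", "known", "first", "only" and "open" are said of these compounds alone.

Compound 3 `COc1ccc2nc(C)cc(OCC(=O)Nc3c(C)cccc3C)c2c1` stands at the edge of a toxicity assay on HepG2 cells (Homo sapiens) for inhibition, read by CellTiter-Glo, with a stated time of 48 h (a lower number here means a stronger inhibitor, a higher number a weaker inhibitor), giving > 100000 nM, which is a boundary of the assay rather than a number. Compound 1 `Cc1cc(C)cc(NC(=O)COc2cc(C)nc3ccc(OCc4ccccc4)cc23)c1` likewise reaches only a limit, > 100000 nM. Compound 2 `CCCc1cc(OCC(=O)Nc2cc(C)cc(C)c2)c2cc(OC)ccc2n1` gives a measured value of 12600 nM. Two of the three compounds thus stop at the boundary (the limit of > 100000 nM in this assay, at which 2 of the 3 values shown sit). Compound 4 `COc1ccc2nc(C)cc(OCC(=O)Nc3ccc(F)cc3)c2c1` differs from compound 3 by 4-fluorophenyl in place of 2,6-dimethylphenyl on an amide-type nitrogen. Going by the values given here, no measured pair in this set differs in exactly one place, so the size of this change is unknown; weak inhibition is expected to persist, with an estimated step of an at least 1.2-fold lower number from compound 3 to compound 4 (0.09 log units; that floor lies within the scatter). Compound 4 is therefore expected to give about 80000 nM, within 20000 nM to 300000 nM, and the assay may well report only a limit again.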

Compound 4, half-maximal inhibitory concentration: 63100 nM
The estimate for compound 4 lay 1.3-fold (0.10 log units) above the measured number, and the stated range covers the measured number.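

Going by these compounds alone, this swap on the amide-type nitrogen gives the first comparison here between compounds that differ in one place, and in this assay it shows an at least 1.5-fold lower number from compound 3 to compound 4 (0.19 log units; that floor lies within the scatter). That step is only a floor, and its true size stays unknown, since one end of it is a limit of the assay: the limit of > 100000 nM in this assay, at which 2 of the 4 values shown sit.

The swap removes the two methyl groups and adds the fluorine together, leaving open which of these changes carries the step. Also open, as far as these compounds go, is how a phenyl ring bearing an amine or a carboxylic acid would read in this assay.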